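Shortening the sulfur chain of compound 3 to a carboxylic acid

The source may report more compounds than this note shows. Statements on the series, on what has been measured and on what is new or still open speak of the compounds shown alone.

Within the data shown here, compound 3 `CCCCCCCCCSc1cc(-c2ccccc2)c(-c2ccccc2)nn1` gives 116000 nM in an assay on microsomes from liver for inhibition of sterol O-acyltransferase 1 (Rattus norvegicus) (a higher number here means a weaker inhibitor, a lower number a stronger inhibitor), the highest of the three numbers known. Compound 2 `CCCCCCCCOc1cc(-c2ccccc2)c(-c2ccccc2)nn1` gives 104000 nM, within the scatter of compound 3, while compound 1 `CCCCCCNc1cc(-c2ccccc2)c(-c2ccccc2)nn1` gives 24000 nM, and the step of a 4.3-fold higher number from compound 1 to compound 2 (0.64 log units; beyond the scatter) is the only one that exceeds the scatter. Compound 4 `O=C(O)CCCCCSc1cc(-c2ccccc2)c(-c2ccccc2)nn1` differs from compound 3 by carboxy in place of butyl on a saturated chain carbon, five bonds along the chain from a sulfur. Among the measured compounds shown here, no measured step replaces part of a chain with a carboxy group, and the sole measured step concerns the linking atom, not the chain end, so it bears little on this change. Compound 4 is therefore expected to change little, with a 1.3-fold higher number from compound 3 to compound 4 (0.11 log units; within the scatter) as the estimate. Compound 4 is estimated at 150000 nM, ranging from 50000 nM to 500000 nM.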

Compound 4, half-maximal inhibitory concentration: > 300000 nM
Compound 4 was reported as a limit; the forecaster's own chance of this, stated with the estimate: 30%; at least 2.0-fold (0.30 log units) between middle value and limit.
By their numbers in this assay, from the lowest: compound 1; then compounds 2 and 3 (each within the scatter of the next). At a limit, above all of these: compound 4.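

In this assay compound 4 gives > 300000 nM, which is a limit. Carboxy in place of butyl at the chain end is the first change shown away from the linking atom, and it moves the number beyond the scatter: an at least 2.5-fold higher number from compound 3 to compound 4 (0.41 log units; beyond the scatter). The gaps to the other chains are also beyond the scatter, with an at least 2.8-fold higher number from compound 2 to compound 4 (0.46 log units; beyond the scatter) and an at least 12-fold higher number from compound 1 to compound 4 (1.09 log units; beyond the scatter), so the end of this chain does matter in this assay. As far as these compounds go, how far compound 4 lies past its limit stays open. So does whether an amide or an ester at the chain end, or a carboxylic acid on a longer chain, would behave the same way.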